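The compounds below may be only part of what the source reports. "The series", "measured", "known", "first", "only" and "open" are said of these compounds alone.

Compound 2 `CN1CCN(c2ccc(Nc3ncc4nc(Nc5ccc(F)cc5)n([C@H]5CCN(C(=O)OC(C)(C)C)C5)c4n3)cc2)CC1` has no result in a functional assay on A-431 cells (Homo sapiens) for antiproliferative activity, read by MTT assay, with a stated time of 72 h; a higher number here means a weaker inhibitor, a lower number a stronger inhibitor; its entry reads "not determined" (no result reported), and no number is reported for it. Among the measured compounds shown here, the one other value shown in this assay comes from compound 1 `CN1CCN(c2ccc(Nc3ncc4nc(Nc5ccc(F)cc5)n([C@@H]5CCN(S(=O)(=O)C6CC6)C5)c4n3)cc2)CC1`, and that value is a limit of the assay rather than a number: compound 1 gives > 10000 nM. That limit is the only anchor available, and it is marked as such (the limit of > 10000 nM in this assay, at which 1 of the 2 values shown sits), so compound 2 stands on no measured footing of its own. The change toward compound 3 `CN1CCN(c2ccc(Nc3ncc4nc(Nc5ccc(F)cc5)n([C@H]5CCCN(C(=O)CO)C5)c4n3)cc2)CC1` is a single replacement on an aromatic nitrogen of the shared core (1-((hydroxymethyl)carbonyl)piperidin-3-yl in place of 1-(tert-butoxycarbonyl)pyrrolidin-3-yl on an aromatic nitrogen). For the measured compounds named here, since no step between measured compounds exists in this assay, no measured size or direction can be carried over to this change. Going by the values given here, the account can only note that the one reported value in this assay is a limit, and that the change from compound 2 to compound 3 replaces a tert-butoxycarbonyl on a pyrrolidine with a (hydroxymethyl)carbonyl on a piperidine, adding one hydrogen-bond donor as counted. With that in mind, compound 3 is estimated at 2000 nM, within an expected range from 200 nM to 10000 nM, and a limit rather than a number remains a real possibility.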

Compound 3, half-maximal inhibitory concentration: 3000 nM
For compound 3 the middle estimate is 1.5-fold (0.18 log units) below the measured one, and the stated range covers the measured number.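

On an aromatic nitrogen of the shared core, 1-((hydroxymethyl)carbonyl)piperidin-3-yl in place of 1-(cyclopropylsulfonyl)pyrrolidin-3-yl gives an at least 3.3-fold lower number from compound 1 to compound 3 (0.52 log units; beyond the scatter) in this assay, and with this the position has its first measured number rather than only a limit. As far as these compounds go, compound 1 gives > 10000 nM, which is a limit of the assay and not a number, so the true size of the step stays unknown and only its direction and lower bound are fixed. The reading therefore rests on one compound with a number and one without: the limit of > 10000 nM in this assay, at which 1 of the 3 values shown sits.

The step from compound 2 to compound 3 cannot be read, as compound 2 has no result, and the step from compound 1 to compound 3 changes both the ring and the group on its nitrogen, leaving the share of each unresolved. From the compounds shown here alone, it remains open how a pyrrolidine bearing the (hydroxymethyl)carbonyl would compare with compound 3, and whether a piperidine carrying a longer hydroxyalkyl chain, a free amine or a carboxylic acid would give a lower or a higher number in this assay.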